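Methoxy for Pentyl on a Core That Shows No Activity

A few compounds are considered here, and "the series" means these few. Any claim that something is new, unique, unknown or untested is made for them only; others in the source may bear on it.

Compound 1 `Cc1ccc(-c2cn(C/C=C3\OC(=O)C(OCc4ccccc4)=C3OCc3ccccc3)nn2)cc1` and compound 2 `CCCCCc1ccc(-c2cn(C/C=C3\OC(=O)C(OCc4ccccc4)=C3OCc3ccccc3)nn2)cc1` share one core and differ only in the chain on the outer phenyl ring. In a functional assay on HCT-116 cells (Homo sapiens) for antiproliferative activity, read by MTT assay, with a stated time of 72 h (on this read-out higher numbers stand for weaker inhibition and lower numbers for stronger inhibition), compound 1 gives > 100000 nM, which is a limit of the assay rather than a number. In this assay compound 2 gives > 100000 nM, again a limit and not a number. The step that the two limits leave unreadable from compound 1 to compound 2 therefore has no readable size; all that can be said is the limit of > 100000 nM in this assay, at which 2 of the 2 values shown sit. Compound 3 `COc1ccc(-c2cn(C/C=C3\OC(=O)C(OCc4ccccc4)=C3OCc3ccccc3)nn2)cc1` differs from compound 2 by methoxy in place of pentyl on an aromatic carbon. Among the measured compounds shown here, the only measured step concerns a change on the same ring and gave no readable size, so there is no ground for expecting a shift beyond the scatter in either direction. Compound 3 is therefore expected to show most likely again only a limit, with an estimate of 100000 nM and a range from 20000 nM to 300000 nM. The step this estimate implies, a number no higher from compound 2 to compound 3 (the limit leaves the size open), is expected to stay within the scatter.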

Compound 3, half-maximal inhibitory concentration: > 100000 nM
Compound 3: only a limit was reported; the forecaster's own chance of this, stated with the estimate: 75%; the middle value lies on the limit itself.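

Among the compounds shown here, no step among compound 1, compound 2 and compound 3 can be read, since each gives a limit of the assay and not a number: the limit of > 100000 nM in this assay, at which 3 of the 3 values shown sit. Going by these compounds, how strongly any of the three inhibits these cells stays open, as does whether methyl, pentyl or methoxy makes any difference.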